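Trading an ortho methyl for a para chlorine on the pendant ring

The source may hold more compounds than are shown below. What is called first, only, known or untested is meant among the compounds shown, and "the series" means these compounds.

Compound 1: `Cc1ccccc1-c1cc(C(C)(C)C)cc(C(C)C)c1CO` — > 50000 nM
Compound 2: `CC(C)c1cc(C(C)(C)C)cc(-c2ccccc2-c2ccccc2)c1CO` — 3200 nM

Both measured compounds share one core and differ only in the group that sits on the ring attached to that core. In a functional assay on RKE cells for antagonist activity at Vasoactive intestinal polypeptide receptor 1 (Rattus norvegicus), read by HTRF and cAMP accumulation, with stated times of 10 min and 30 min (on this read-out lower numbers stand for stronger inhibition and higher numbers for weaker inhibition), compound 1 gives > 50000 nM, which is a limit of the assay rather than a number. Compound 2 gives 3200 nM. Within the data shown here, the single measured step, an at least 15-fold lower number from compound 1 to compound 2 (1.19 log units; beyond the scatter), is therefore large, and it starts from a limit (the limit of > 50000 nM in this assay, at which 1 of the 2 values shown sits).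

Compound 3 is `CC(C)c1cc(C(C)(C)C)cc(-c2ccc(Cl)cc2)c1CO`. Its change from compound 1 is 4-chlorophenyl in place of 2-methylphenyl on an aromatic carbon. Among the measured compounds shown here, no measured step matches this change exactly. For the measured compounds named here, what bears on it is that the only measured step, an at least 15-fold lower number from compound 1 to compound 2 (1.19 log units; beyond the scatter), shows the pendant ring's substituent can move the read-out a great deal away from the limit of compound 1, but compound 3 carries neither the phenyl of compound 2 nor the methyl of compound 1.

Compound 3 is therefore expected to sit between the two measured values, at an estimated 12000 nM, within a range of 2500 nM to 50000 nM, meaning an expected step of an at least 4.1-fold lower number from compound 1 to compound 3 (0.61 log units; beyond the scatter).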

Compound 3, half-maximal inhibitory concentration: 290 nM
For compound 3 the middle estimate is 41-fold (1.62 log units) above the measured one; measured number below the stated range.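

In this assay, the change from 2-methylphenyl to 4-chlorophenyl gives an at least 170-fold lower number from compound 1 to compound 3 (2.23 log units; beyond the scatter), even though the two groups have the same count of heavy atoms, each is one six-membered aromatic ring of carbon only, and neither has a hydrogen-bond donor, a hydrogen-bond acceptor or a net charge. A second aromatic ring on the pendant ring is therefore not needed for a low number at this position, ortho to a hydroxymethyl group: compound 2, which has one, gives 3200 nM, whereas compound 3, which has none, gives 290 nM. The value of compound 1 is a limit of the assay and not a number, and the step starts from it: the limit of > 50000 nM in this assay, at which 1 of the 3 values shown sits.

The compounds shown cannot separate losing the methyl from gaining the chlorine, since the two substituents differ in both identity and place on the pendant ring, and an unsubstituted phenyl would be the direct reference for each. From the compounds shown here alone, it also remains open whether the chlorine could give way to a methoxy group, an amine or a carboxylic acid.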